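Methyl in place of hydrogen on an aromatic nitrogen

A few compounds are considered here, and "the series" means these few. Any claim that something is new, unique, unknown or untested is made for them only; others in the source may bear on it.

Measured so far:
compound 1 `C(=C\c1ccc2[nH]ccc2c1)\c1ccc2ccccc2c1`: > 5000 nM
compound 2 `Cn1ccc2cc(/C=C\c3ccc4ccccc4c3)ccc21`: > 5000 nM
compound 3 `COc1cc(/C=C/c2c[nH]c3ccccc23)cc(OC)c1OC`: 3230 nM

In a functional assay on A549 cells (Homo sapiens) for inhibition (a lower number here means a stronger inhibitor, a higher number a weaker inhibitor), compound 1 reaches only a limit, > 5000 nM. Compound 2 likewise reaches only a limit in this assay, > 5000 nM. For the measured compounds named here, compound 3 is the one compound with a number in this assay, 3230 nM.

Compound 1 and compound 2 differ by methyl in place of hydrogen on an aromatic nitrogen. The size of this step, a step that the two limits leave unreadable from compound 1 to compound 2, cannot be read, because the limit of > 5000 nM in this assay, at which 2 of the 3 values shown sit, holds both ends of the pair. The core of compound 3 differs from the core of compound 1, but that difference is not broken down here.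

Compound 4 `COc1cc(/C=C/c2cn(C)c3ccccc23)cc(OC)c1OC`, not yet measured in this assay, is related to compound 3 by methyl in place of hydrogen on an aromatic nitrogen. This is the same kind of change as the step from compound 1 to compound 2, though around the place it differs: in compound 3 the ring atom two ring bonds away bears a large group. The measured pair gives no readable size for the methyl, so the expectation for compound 4 rests on compound 3 alone, whose 3230 nM sets the starting point. The step from compound 3 to compound 4 is expected to be about a 1.1-fold lower number from compound 3 to compound 4 (0.03 log units; within the scatter). Compound 4 is therefore estimated at 3000 nM in this assay, with a wide range of 800 nM to 12000 nM.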

Compound 4, half-maximal inhibitory concentration: 3090 nM
Estimate against measurement, compound 4: 1.0-fold (0.01 log units) below; low and high end bracket the measured number.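

On the core of compound 3, methyl in place of hydrogen on an aromatic nitrogen gives in this assay a 1.0-fold lower number from compound 3 to compound 4 (0.02 log units; within the scatter), so on this core the hydrogen on that nitrogen can be exchanged for methyl without a change beyond the scatter. For the compounds shown here, the same change on the core of compound 1 cannot be read, because both ends of that pair sit at a limit, which gives no size for the step: the limit of > 5000 nM in this assay, at which 2 of the 4 values shown sit. The series therefore holds one readable instance of this change, on one core, and shows neither that the result carries over to the core of compound 1 nor that it fails to, so any transfer from one core to the other remains an assumption.

As far as these compounds go, whether a larger group on the same aromatic nitrogen, such as ethyl, a longer chain, or a chain ending in an amine or a carboxylic acid, would move the number in this assay remains open on both cores. Also open, from the compounds shown here alone, is how the core of compound 3 would respond if one of its methoxy groups gave way to a hydroxyl or a fluorine.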